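Series notes: imidazolyl end group on the sulfanyl chain

The source may report more compounds than this note shows. Statements on the series, on what has been measured and on what is new or still open speak of the compounds shown alone.

Values from a functional assay on HT cells (Homo sapiens) for antiproliferative activity, read by fluorescence, with a stated time of 72 h (on this read-out higher numbers stand for weaker inhibition of growth and lower numbers for stronger inhibition of growth), follow
- compound 1 `CC(C)c1n[nH]c2c(NCc3ccc(-c4ccccn4)cc3)nc(SCCNC(=N)N)nc12` gives 390 nM
- compound 2 `CSCCSc1nc(NCc2ccc(-c3ccccn3)cc2)c2[nH]nc(C(C)C)c2n1` gives 975 nM

Compound 2 stands highest of the two numbers, with 975 nM as the weaker inhibition of growth. The next structure is compound 3 `CC(C)c1n[nH]c2c(NCc3ccc(-c4ccccn4)cc3)nc(SCCn3ccnc3)nc12` and the change is 1H-imidazol-1-yl in place of methylsulfanyl on a saturated chain carbon, two bonds along the chain from a sulfur with the rest of the structure kept. Among the compounds with values here, the only measured step that bears on this is a 2.5-fold higher number from compound 1 to compound 2 (0.40 log units; beyond the scatter) in this assay and it is modest. Within the data shown here, that step concerns a different end group, and no measured compound carries 1H-imidazol-1-yl, so it is an indirect guide. The lower number belongs to compound 1 at 390 nM and a small move in that direction is expected, no larger than the measured step. The expected change is a 1.6-fold lower number from compound 2 to compound 3 (0.21 log units; within the scatter) as an estimate. Compound 3 is expected at 600 nM with an estimated range of 250 nM to 1500 nM in this assay.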

Compound 3, concentration for 50% growth inhibition: 155 nM
For compound 3 the middle estimate is 3.9-fold (0.59 log units) above the measured one; measured number outside the range, below it.
By their numbers in this assay, from the lowest: compound 3; then compound 1; then compound 2.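

In this assay, 1H-imidazol-1-yl in place of methylsulfanyl, on a saturated chain carbon, two bonds along the chain from a sulfur, gives a 6.3-fold lower number from compound 2 to compound 3 (0.80 log units; beyond the scatter). The same ring also improves on the previous lowest number, with a 2.5-fold lower number from compound 1 to compound 3 (0.40 log units; beyond the scatter), so a five-membered aromatic ring is tolerated at the chain end and the non-ring end group of the earlier best compound does not mark the limit of this position. Nothing measured in this series speaks to the reason for either step.

Within the data shown here, compound 3 is the only compound here with a ring at the chain end, so it remains open whether a phenyl ring would serve as well as 1H-imidazol-1-yl. Also open, going by these compounds, is whether a longer chain carrying the same ring, or a plain amine at the chain end, would hold the number of compound 3.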